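The compounds below may be only part of what the source reports. "The series", "measured", "known", "first", "only" and "open" are said of these compounds alone.

Working notes on the series. Compound 1 `CC1(C)[C@H]2CC[C@]1(C)N(Cc1cn(-c3ccccc3C#N)nn1)C(=O)C2` gives 110 nM in a functional assay on OVCAR-3 cells (Homo sapiens) for inhibition, read by MTT assay, with a stated time of 24 h (on this read-out higher numbers stand for weaker inhibition and lower numbers for stronger inhibition), the lowest of the three numbers in hand. Compound 2 `CC1(C)[C@H]2CC[C@]1(C)N(Cc1cn(-c3ccc(F)cc3)nn1)C(=O)C2` gives 200 nM and compound 3 `CC1(C)[C@H]2CC[C@]1(C)N(Cc1cn(-c3ccc(O)cc3)nn1)C(=O)C2` gives 410 nM. Both exchanges of the 2-cyanophenyl raised the number: a 1.8-fold higher number from compound 1 to compound 2 (0.26 log units; within the scatter) and a 3.7-fold higher number from compound 1 to compound 3 (0.57 log units; beyond the scatter).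

Compound 4 `Cc1cccc(-n2cc(CN3C(=O)C[C@@H]4CC[C@@]3(C)C4(C)C)nn2)c1` is not yet measured. Its change from compound 1 is 3-methylphenyl in place of 2-cyanophenyl on an aromatic nitrogen. Among the measured compounds shown here, no measured compound carries 3-methylphenyl, so only the two exchanges of 2-cyanophenyl above bear on it; both point to a weaker result of modest size. A similar step is therefore expected here, upward, at the edge of the scatter: a 2.0-fold higher number from compound 1 to compound 4 (0.30 log units; within the scatter). Compound 4 is estimated at 220 nM, with a range of 100 nM to 480 nM.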

Compound 4, half-maximal inhibitory concentration: 160 nM
For compound 4 the middle estimate is 1.4-fold (0.14 log units) above the measured one, and the stated range covers the measured number.
By their numbers in this assay, from the lowest: compounds 1, 4 and 2 (each within the scatter of the next); then compound 3.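

At this place on the aromatic nitrogen, 3-methylphenyl, with no nitrile and no hydrogen-bond acceptor, stays within the scatter of 2-cyanophenyl (a 1.5-fold higher number from compound 1 to compound 4 (0.16 log units; within the scatter)), so a nitrile is not required for a number of this order in this assay. It also stays within the scatter of 4-fluorophenyl (a 1.3-fold lower number from compound 2 to compound 4 (0.10 log units; within the scatter)), while 4-hydroxyphenyl stands apart from it (a 2.6-fold lower number from compound 3 to compound 4 (0.41 log units; beyond the scatter)). No measurement in hand bears on why the numbers fall this way.

Still open, on these data alone, is how this position responds to an amine or a carboxylic acid on the phenyl ring, or to a longer chain in place of the methyl.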